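One Ring Enlargement, Made a Second Time

This account rests on a few compounds, and the source may have more. Where it says the series, first, only, none or still open, it means among the compounds named here.

Compound 1 `CN(c1cccc2ccccc12)S(=O)(=O)c1ccc2c(c1)sc(=O)n2CCN1CCCC1`: 40%
Compound 2 `CN(c1cccc2ccccc12)S(=O)(=O)c1ccc2c(c1)sc(=O)n2CCN1CCCCC1`: 14%
Compound 3 `O=c1sc2cc(S(=O)(=O)Nc3ccccc3)ccc2n1CCN1CCCC1`: 37%

All three compounds were tested in an assay on HEK293 cells for displacement of a labelled ligand from 5-hydroxytryptamine receptor 6 (Homo sapiens), read by radioligand binding, with a stated time of 60 min, tested at 100 nM; a lower number here means less inhibition, a higher number more inhibition at the concentration tested (going by the name of the read-out). Compound 1 and compound 2 share one core and differ in a single place: piperidin-1-yl in place of pyrrolidin-1-yl on a saturated chain carbon, two bonds along the chain from an aromatic nitrogen. That change produced a number 26 percentage points lower from compound 1 to compound 2 (beyond the scatter).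

Compound 3 carries a different core; the difference between the core of compound 1 and the core of compound 3 is not broken down here. In this assay compound 3 gives 37%, a number within the scatter of what compound 1 gives, while compound 2 gives a number beyond the scatter below it.

Compound 4 `O=c1sc2cc(S(=O)(=O)Nc3ccccc3)ccc2n1CCN1CCCCC1` has not been measured yet. Among the compounds with values here, it differs from compound 3 by piperidin-1-yl in place of pyrrolidin-1-yl on a saturated chain carbon, two bonds along the chain from an aromatic nitrogen, which is the same change, at the same place, as the one from compound 1 to compound 2.

Within the data shown here, with only one earlier example of this change, the expectation rests on a single step, and on the observation that compound 3 and compound 1 start from numbers within the scatter of each other. For compound 4 the expected step is a number 24 percentage points lower from compound 3 to compound 4 (beyond the scatter). That expectation rests on the earlier change, which gave a number 26 percentage points lower from compound 1 to compound 2 (beyond the scatter). Compound 4 is therefore estimated at 13% in this assay, with a likely range from 0% to 30%.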

Compound 4, a percentage reported as inhibition, at one concentration (the size of the read-out at that concentration, not a potency): 7%
The estimate for compound 4 lay 6 percentage points above the measured number; low and high end bracket the measured number.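

In this assay, the same ring enlargement on the second core gave a number 30 percentage points lower from compound 3 to compound 4 (beyond the scatter), and this matches the earlier step closely: the same change on two cores in this assay, a number 26 percentage points lower (beyond the scatter) from compound 1 to compound 2 and a number 30 percentage points lower (beyond the scatter) from compound 3 to compound 4, 4 percentage points apart, within the scatter of two such steps

Within these four compounds, then, the swap of pyrrolidin-1-yl for piperidin-1-yl carried over from one core to the other, with a drop of about the same size on both, so the step seen on the first core was a fair guide to the second. Within the data shown here, this does not show a general rule, since two cores are only two examples, and each number is an inhibition reading at a single concentration rather than a potency, so neither step says how far the affinity itself moved or why the larger ring gives the lower number.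

The compounds shown leave open how other groups on the same chain would behave, such as an open-chain dimethylamino group or a morpholin-4-yl ring, and whether a longer chain carrying either of the two rings would give the same drop. Also open, on these data alone, is whether the step would keep its size on a third core.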